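From 3-chlorophenyl to 2-methoxyphenyl on a shared core

The source may report more compounds than this note shows. Statements on the series, on what has been measured and on what is new or still open speak of the compounds shown alone.

Compound 1 `COc1cccc(/C=C2\CCC/C(=C\c3ccccc3Cl)C2=O)c1OC` gives 10300 nM
Compound 2 `COc1cccc(/C=C2\CCC/C(=C\c3cccc(Cl)c3Cl)C2=O)c1OC` gives 16300 nM
Compound 3 `COc1ccc(/C=C2\CCC/C(=C\c3cccc(Cl)c3)C2=O)cc1OC` gives 5100 nM

In a functional assay on SW-620 cells (Homo sapiens) for cytotoxicity, read by MTT assay, with a stated time of 72 h (on this read-out lower numbers stand for stronger inhibition and higher numbers for weaker inhibition), compound 3 stands lowest of the three at 5100 nM on these numbers. Compound 4 `COc1ccccc1/C=C1\CCC/C(=C\c2ccc(OC)c(OC)c2)C1=O` awaits measurement and differs from compound 3 thus: 2-methoxyphenyl in place of 3-chlorophenyl on a double-bonded chain carbon bound to a double-bonded ring carbon in a swap of 2-methoxyphenyl for 3-chlorophenyl. For the measured compounds named here, the only measured step is a 1.6-fold higher number from compound 1 to compound 2 (0.20 log units; within the scatter) and it is a chloro in place of hydrogen on an aromatic carbon, so it does not test this exchange directly. Compound 1 at 10300 nM and compound 2 at 16300 nM both sit higher than compound 3, so a modest move to a higher number is expected in this assay and nothing large. The expected step is a 1.6-fold higher number from compound 3 to compound 4 (0.20 log units; within the scatter) by this estimate. Compound 4 is estimated at 8000 nM with 2800 nM to 20000 nM as its expected range.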

Compound 4, half-maximal inhibitory concentration: 7800 nM
For compound 4 the middle estimate is 1.0-fold (0.01 log units) above the measured one, within the range that was stated.
By their numbers in this assay, from the lowest: compounds 3, 4, 1 and 2 (each within the scatter of the next, the first and the last beyond it).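

In this assay, for the compounds shown here, the exchange gives a 1.5-fold higher number from compound 3 to compound 4 (0.18 log units; within the scatter), the first direct reading at this position, on a double-bonded chain carbon bound to a double-bonded ring carbon. So 2-methoxyphenyl, which adds a hydrogen-bond acceptor to the count, can stand in place of 3-chlorophenyl without a step beyond the scatter. Nothing available explains this outcome.

As far as these compounds go, whether an amine or a carboxylic acid in place of the methoxy group would leave the number equally undisturbed remains open. So does whether any group at this position can produce a step beyond the scatter.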